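The compounds below may be only part of what the source reports. "The series", "measured", "known", "first", "only" and "open" are said of these compounds alone.

Working notes on the series, read in a functional assay on HL-60 cells (Homo sapiens) for inhibition, read by MTT assay, with a stated time of 48 h, tested at 10 uM (a lower number here means less inhibition of growth, a higher number more inhibition of growth at the concentration tested), at a single concentration. Compound 1 `COc1ccc(COc2cc(O)c3c(=O)cc(C)oc3c2[C@H]2CCN(C)C[C@H]2O)cc1` gives 23% in this read-out, compound 2 `Cc1cc(=O)c2c(O)c(CN3CC(O)CC3C(=O)O)c(O)c([C@H]3CCN(C)C[C@H]3O)c2o1` gives 28% and compound 3 `Cc1oc2c([C@H]3CCN(C)C[C@H]3O)c(O)cc(O)c2c(=O)c1C(O)c1ccc(F)c(Br)c1` gives 25% on the same plate format. Compound 3 lies within the scatter of both compound 1 and compound 2, so the three numbers form one band with no order among them.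

Compound 4 `Cc1oc2c([C@H]3CCN(C)C[C@H]3O)c(O)cc(O)c2c(=O)c1C(O)c1ccc(F)cc1` has not yet been measured in this assay and departs from compound 3 in one place: hydrogen in place of bromo on an aromatic carbon on an aromatic carbon of a six-membered aromatic ring of carbon only, ortho to a fluoro group and meta to a large group. The 3-bromo-4-fluorophenyl becomes 4-fluorophenyl, with the hydroxy carbon that carries it unchanged.

Among the compounds with values here, no measured pair differs in a single place, so the data show no direct size for this step. The three measured compounds carry quite different groups and still stay within the scatter of one another. On that basis, no step beyond the scatter is expected, and no direction is favoured. The estimated shift is a number 2 percentage points lower from compound 3 to compound 4 (within the scatter) and remains an expectation only. For compound 4 the estimated value is 23% with an expected range from 11% to 36% until the measurement arrives.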

Compound 4, percent growth inhibition at one concentration: 30%
The estimate for compound 4 lay 7 percentage points below the measured number; measured number inside the range.
By their numbers in this assay, from the lowest: compounds 1, 3, 2 and 4 (each within the scatter of the next).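

In this assay the series now has its first step in a single place, hydrogen in place of bromo on an aromatic carbon, ortho to a fluoro group and meta to a large group, and it reads a number 5 percentage points higher from compound 3 to compound 4 (within the scatter) as measured. Within the data shown here, at this position, then, the bromo can be lost without a step beyond the scatter, and the 3-bromo-4-fluorophenyl and 4-fluorophenyl compounds cannot be told apart by this read-out at the single concentration tested, which the earlier compounds, differing in more than one place, could not show. No supporting data bear on the reason for the size of this step.

On these data alone, one replacement at one aromatic carbon says little about the position in general, and whether a nitrile, a morpholine or a trifluoromethyl group there would stay inside the same band remains open. Also open, as far as these compounds go, is whether the fluoro group matters on the 4-fluorophenyl, and whether the near equality of these two compounds would hold at other concentrations.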